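Carbamate in place of oxolane amide at the pyrazole amine

The compounds below may be only part of what the source reports. "The series", "measured", "known", "first", "only" and "open" are said of these compounds alone.

Measured so far:
- compound 1, `Cc1cc(C(=O)Nc2ccccc2)nn1Cc1cc(Cl)ccc1OCc1ccccc1`: 39.8 nM
- compound 2, `Cc1cc(C(=O)Nc2c(F)cccc2F)nn1Cc1cc(Cl)ccc1OCc1ccccc1`: 10 nM
- compound 3, `Cc1cc(NC(=O)C2CCOC2)nn1Cc1cc(Cl)ccc1OCc1ccccc1`: 39.8 nM

In an assay on CHO-K1 cells for displacement of a labelled ligand from prostaglandin E2 receptor EP1 subtype (Homo sapiens) (a higher number here means a weaker inhibitor, a lower number a stronger inhibitor), compound 3 stands level with compound 1 at the digits shown, the two together at the high end of the three numbers; compound 2 sits furthest from it, a 4.0-fold higher number from compound 2 to compound 3 (0.60 log units; beyond the scatter). Compound 4, `Cc1cc(NC(=O)OCc2ccccc2)nn1Cc1cc(Cl)ccc1OCc1ccccc1`, differs from compound 3 by benzyloxy in place of oxolan-3-yl on a carbonyl carbon. Among the measured compounds shown here, no measured step exchanges these two groups. For the measured compounds named here, the only step at the same position, no change at the digits printed from compound 1 to compound 3 (within the scatter), shows that a change of the whole amide unit can pass without effect in this assay, while a 4.0-fold lower number from compound 1 to compound 2 (0.60 log units; beyond the scatter) concerns a different position. Without a precedent, no step beyond the scatter is expected, so for compound 4 the estimate is 35 nM (range 9 nM to 140 nM), an expected step of a 1.1-fold lower number from compound 3 to compound 4 (0.06 log units; within the scatter).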

Compound 4, half-maximal inhibitory concentration: 79.4 nM
For compound 4 the middle estimate is 2.3-fold (0.36 log units) below the measured one; low and high end bracket the measured number.
By their numbers in this assay, from the lowest: compound 2; then compounds 1, 3 and 4 (each within the scatter of the next).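

In this assay, the carbonyl carbon on the amide-type nitrogen accepts benzyloxy in place of oxolan-3-yl, with the step, a 2.0-fold higher number from compound 3 to compound 4 (0.30 log units; within the scatter), showing that the aromatic ring can enter without a change that can be read. The (benzyloxycarbonyl)amino group also stays level with the phenylcarbamoyl unit, a 2.0-fold higher number from compound 1 to compound 4 (0.30 log units; within the scatter), whereas the (2,6-difluorophenyl)carbamoyl unit remains apart, a 7.9-fold higher number from compound 2 to compound 4 (0.90 log units; beyond the scatter). No evidence at hand accounts for these steps.

Still open, as far as these compounds go, is whether a benzylamino group on the carbonyl carbon, or a longer chain in place of benzyloxy, holds this level. Also open, from the compounds shown here alone, is whether fluorine atoms on the benzyloxy ring act as they do in compound 2.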